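Dropping One Trifluoromethyl From a Urea Tail

The source may hold more compounds than are shown below. What is called first, only, known or untested is meant among the compounds shown, and "the series" means these compounds.

Measured so far:
compound 1 `O=C(Nc1cccc(-n2cc(-c3ccncc3)c(-c3cc(O)cc(Cl)c3)n2)c1)Nc1ccc(Cl)c(C(F)(F)F)c1`: -85%
compound 2 `COc1cc(Cl)cc(-c2nn(-c3cccc(NC(=O)Nc4cc(C(F)(F)F)cc(C(F)(F)F)c4)c3)cc2-c2ccncc2)c1`: -71%

Both compounds were tested in a functional assay on UACC-62 cells (Homo sapiens) for inhibition, read by sulforhodamine B assay, with a stated time of 48 h, tested at 100 uM; on this read-out higher numbers stand for a weaker effect at the one concentration tested and lower numbers for a stronger effect. Compound 1 gives -85%, and compound 2 gives -71%. Of these two numbers, compound 2 stands highest, and its gap to compound 1 lies beyond the usual scatter, so compound 2 shows the weaker effect at the one concentration tested.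

Compound 3 `COc1cc(Cl)cc(-c2nn(-c3cccc(NC(=O)Nc4cccc(C(F)(F)F)c4)c3)cc2-c2ccncc2)c1` has not yet been measured. It differs from compound 2 in one place: hydrogen in place of trifluoromethyl on an aromatic carbon. Going by the values given here, no step between two measured compounds shows the effect of such a change, so the expectation rests only on the two values shown. A small step toward a higher number in this assay is expected, though it may stay within the scatter. For compound 3 the estimate is -60%, with a range from -85% to -25%, which means an expected step of a number 11 percentage points higher from compound 2 to compound 3 (beyond the scatter).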

Compound 3, a percentage reported as activity, at one concentration (the size of the read-out at that concentration, not a potency): -82%
The estimate for compound 3 lay 22 percentage points above the measured number; measured number inside the range.
By their numbers in this assay, from the lowest: compounds 1 and 3 (each within the scatter of the next); then compound 2.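

In this assay, putting hydrogen in place of one trifluoromethyl on the urea tail gives a number 11 percentage points lower from compound 2 to compound 3 (beyond the scatter) and so a modestly stronger effect at the one concentration tested. This shows that the second trifluoromethyl at this position is not needed for the effect, and that the read-out here improves without it, although a single concentration says nothing about potency. Nothing measured here accounts for why the number moves in this direction.

The compounds shown leave open whether a small atom such as fluorine, or a group such as an amine or a carboxylic acid, on this same aromatic carbon would match hydrogen. They also leave open what would happen if the remaining trifluoromethyl were replaced by hydrogen as well.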